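The source may hold more compounds than are shown below. What is called first, only, known or untested is meant among the compounds shown, and "the series" means these compounds.

Compound 1 `COc1ccc(-n2ccnc2-c2cc(OC)c(OC)c(OC)c2)cc1[N+](=O)[O-]` and compound 2 `COc1ccc(-n2ccnc2-c2cc(OC)c(OC)c(OC)c2)cc1N` share one core and differ by a single change, (amino in place of nitro on an aromatic carbon). Among the compounds with values here, in a functional assay on MDA-MB-231 cells (Homo sapiens) for antiproliferative activity, read by MTT assay, with a stated time of 72 h (on this read-out higher numbers stand for weaker inhibition and lower numbers for stronger inhibition), compound 1 gives 7500 nM, while compound 2 gives 1040 nM, and the step of a 7.2-fold lower number from compound 1 to compound 2 (0.86 log units; beyond the scatter) is the only measured example of this change. Compound 3 `COc1ccc(NC(=O)c2cc(OC)c(OC)c(OC)c2)cc1[N+](=O)[O-]` carries a different core; how the two cores differ is not broken down here. In this assay compound 3 gives 31000 nM, the highest of the three numbers. Compound 4 `COc1ccc(NC(=O)c2cc(OC)c(OC)c(OC)c2)cc1N` is not yet measured; it relates to compound 3 by amino in place of nitro on an aromatic carbon, the same change as that between compound 1 and compound 2, at the same place. Within the data shown here, compound 4 is therefore expected to show a step of about a 6.2-fold lower number from compound 3 to compound 4 (0.79 log units; beyond the scatter), resting on the step of a 7.2-fold lower number from compound 1 to compound 2 (0.86 log units; beyond the scatter), though only one prior example supports it and the core of compound 3 differs from that of compound 1. In this assay compound 4 is estimated at 5000 nM, with a likely range from 1500 nM to 15000 nM.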

Compound 4, half-maximal inhibitory concentration: 18600 nM
Estimate against measurement, compound 4: 3.7-fold (0.57 log units) below; measured number above the stated range.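

In this assay, placing amino in place of nitro on the second core gives a 1.7-fold lower number from compound 3 to compound 4 (0.22 log units; within the scatter), so on this core the change does not separate the two compounds beyond the usual variation between repeats. Set beside the earlier step, the change does not carry over at the same size from one core to the other: the same change on two cores in this assay, a 7.2-fold lower number (0.86 log units; beyond the scatter) from compound 1 to compound 2 and a 1.7-fold lower number (0.22 log units; within the scatter) from compound 3 to compound 4, 4.3-fold (0.64 log units) apart, beyond the scatter of two such steps

This shows that, in this series, the step measured on one core was not a reliable guide to its size on the other, but with a single pair on each core it does not show what sets the two steps apart or how the change would behave on any further core.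

The compounds shown leave open how a hydroxyl, a chlorine atom or an acetylated amine, on the same aromatic carbon ortho to a methoxy group, would read in this assay on either core. They also leave open whether a third core would follow the step seen on the first core, the step seen on the second, or neither.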